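A few compounds are considered here, and "the series" means these few. Any claim that something is new, unique, unknown or untested is made for them only; others in the source may bear on it.

The account begins with `CC(C)(C)OC(=O)N1CCC(O[C@H]2CC[C@H](Oc3ccc(S(C)(=O)=O)cc3F)CC2)CC1`, compound 1, which in an assay on isolated protein for agonist activity at Glucose-dependent insulinotropic receptor (Homo sapiens) (a higher number here means that more compound is needed for the effect, a lower number that less compound is needed), gives 227 nM. Among the compounds with values here, compound 2, `CC(C)OC(=O)N1CCC(O[C@H]2CC[C@H](Oc3cnc(S(C)(=O)=O)cn3)CC2)CC1`, gives 92.7 nM in this assay, the lower of the two numbers so far, and the gap to compound 1 lies beyond the usual scatter. Compound 3, `CC(F)Cc1nc(CN2CCC(O[C@H]3CC[C@H](Oc4cnc(S(C)(=O)=O)cn4)CC3)CC2)no1`, differs from compound 2 by (5-(2-fluoropropyl)-1,2,4-oxadiazol-3-yl)methyl in place of isopropoxycarbonyl on an amine nitrogen in a ring. Within the data shown here, no measured pair shows this change, so the expectation rests on the two values alone: a moderate lowering of the number is expected, a 2.3-fold lower number from compound 2 to compound 3 (0.37 log units; beyond the scatter). Compound 3 is accordingly estimated at 40 nM, with a range from 10 nM to 160 nM.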

Compound 3, half-maximal effective concentration: 276 nM
Compound 3: middle estimate off by 6.9-fold (0.84 log units), on the low side, outside the stated range (above it).
By their numbers in this assay, from the lowest: compound 2; then compounds 1 and 3 (each within the scatter of the next).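

On the amine nitrogen in the ring, (5-(2-fluoropropyl)-1,2,4-oxadiazol-3-yl)methyl in place of isopropoxycarbonyl gives a 3.0-fold higher number from compound 2 to compound 3 (0.47 log units; beyond the scatter) in this assay. Within the data shown here, this is the first single-place comparison in the account: it shows that this position responds to the group it carries and that, of these two groups, isopropoxycarbonyl needs less compound for the effect. Nothing available explains this step. Open, going by these compounds, is whether the fluorine matters, since a plain propyl chain on the same ring could give a different number, and whether the methyl linker contributes to the step.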